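From 3-methylpiperidin-1-yl to (2-anilinoethyl)amino on a carbonyl carbon

The compounds below may be only part of what the source reports. "The series", "measured", "known", "first", "only" and "open" are said of these compounds alone.

In a functional assay on HCT-116 cells (Homo sapiens) for antiproliferative activity, read by MTT assay, with a stated time of 48 h (on this read-out higher numbers stand for weaker inhibition and lower numbers for stronger inhibition), three compounds sharing one core have been measured. Compound 1 `Cc1c(C(=O)NCCCN(C)C)oc2ccc(N(Cc3ccc(Br)cc3)S(=O)(=O)c3ccc(Br)cc3)cc12` gives 3730 nM, compound 2 `Cc1c(C(=O)NCC(O)CO)oc2ccc(N(Cc3ccc(Br)cc3)S(=O)(=O)c3ccc(Br)cc3)cc12` gives 11500 nM and compound 3 `Cc1c(C(=O)N2CCCC(C)C2)oc2ccc(N(Cc3ccc(Br)cc3)S(=O)(=O)c3ccc(Br)cc3)cc12` gives 28300 nM. Compound 3 therefore has the highest number of the three, which makes it the weakest inhibitor so far.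

Compound 4 `Cc1c(C(=O)NCCNc2ccccc2)oc2ccc(N(Cc3ccc(Br)cc3)S(=O)(=O)c3ccc(Br)cc3)cc12` is still unmeasured. It carries (2-anilinoethyl)amino in place of 3-methylpiperidin-1-yl on a carbonyl carbon.

Among the compounds with values here, no measured step makes exactly this swap, but two come close. Each of them ends at the same 3-methylpiperidin-1-yl group. Going to that group gave a 7.6-fold higher number from compound 1 to compound 3 (0.88 log units; beyond the scatter) and a 2.5-fold higher number from compound 2 to compound 3 (0.39 log units; beyond the scatter). Both steps are modest, and both start from an amino chain on the carbonyl carbon, as compound 4 has. Leaving that group for a chain should therefore lower the number. The size remains uncertain, since neither measured chain holds an anilino group, and the two chains themselves differ by a 3.1-fold higher number from compound 1 to compound 2 (0.49 log units; beyond the scatter).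

The expected change is a 3.1-fold lower number from compound 3 to compound 4 (0.50 log units; beyond the scatter). For compound 4 the estimated value is 9000 nM, with an expected range from 3500 nM to 23000 nM.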

Compound 4, half-maximal inhibitory concentration: > 40000 nM
Compound 4: a limit, no number; the forecaster's own chance of this, stated with the estimate: 5%; middle value at least 4.4-fold (0.64 log units) away from the limit.
By their numbers in this assay, from the lowest: compound 1; then compound 2; then compound 3. At a limit, above all of these: compound 4.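

In this assay compound 4 gives no number, only a limit: the limit of > 40000 nM in this assay, at which 1 of the 4 values shown sits.

The earlier compounds shown here suggested that an amino chain on the carbonyl carbon keeps the number below that of the 3-methylpiperidin-1-yl ring, as compound 1 and compound 2 do, but the chain ending in anilino goes against this. It gives an at least 10-fold higher number from compound 1 to compound 4 (1.03 log units; beyond the scatter) and an at least 3.4-fold higher number from compound 2 to compound 4 (0.54 log units; beyond the scatter), so at this position the result depends on the particular chain and not simply on having a chain in place of the ring. The remaining comparison is an at least 1.4-fold higher number from compound 3 to compound 4 (0.15 log units; that floor lies within the scatter), and since that floor lies within the scatter, compound 4 cannot yet be placed apart from compound 3, even though the true value could lie well beyond the limit.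

Compound 1 and compound 4 differ in the length of the chain as well as in its end group, so (2-(dimethylamino)ethyl)amino on the carbonyl carbon would be needed to tell which of the two matters. On these data alone, it also remains open whether other chain ends, such as a morpholine or a carboxylic acid, would fall nearer compound 1 or nearer compound 4.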